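Shrinking the Ether-Linked Ring on a Bcl-2 Sulfonamide

A few compounds are considered here, and "the series" means these few. Any claim that something is new, unique, unknown or untested is made for them only; others in the source may bear on it.

Two close analogues have been measured in an assay on isolated protein for displacement of a labelled ligand from Apoptosis regulator Bcl-2 (Homo sapiens), with a stated time of 15 min; on this read-out higher numbers stand for weaker inhibition and lower numbers for stronger inhibition. Compound 1 `CC1(C)CCC(CN2CCN(c3ccc(C(=O)NS(=O)(=O)c4ccc(NCC5CCOCC5)c([N+](=O)[O-])c4)c(Oc4cnc5[nH]ccc5c4)c3)CC2)=C(c2ccc(C(F)(F)F)cc2)C1` gives 1.5 nM. Compound 2 `CC1(C)CCC(CN2CCN(c3ccc(C(=O)NS(=O)(=O)c4ccc(OCC5CCOCC5)c([N+](=O)[O-])c4)c(Oc4cnc5[nH]ccc5c4)c3)CC2)=C(c2ccc(C(F)(F)F)cc2)C1` gives 1 nM, the lowest of the two numbers, though the gap to compound 1 is within the scatter: a 1.5-fold lower number from compound 1 to compound 2 (0.18 log units; within the scatter). Compound 3 `CC1(C)CCC(CN2CCN(c3ccc(C(=O)NS(=O)(=O)c4ccc(OCC5CCOC5)c([N+](=O)[O-])c4)c(Oc4cnc5[nH]ccc5c4)c3)CC2)=C(c2ccc(C(F)(F)F)cc2)C1` differs from compound 2 by oxolan-3-yl in place of oxan-4-yl on a saturated chain carbon bound to an oxygen on an aromatic ring, so the six-membered ring gives way to a five-membered one while the rest of the molecule is kept. Among the measured compounds shown here, the single measured step concerns the link between this ring and the aromatic ring, not the ring itself, and it stayed within the scatter, so nothing measured speaks for a shift in either direction. The expected step is therefore small, a 1.2-fold higher number from compound 2 to compound 3 (0.08 log units; within the scatter). Compound 3 is estimated at 1.2 nM, within a range from 0.5 nM to 3 nM.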

Compound 3, half-maximal inhibitory concentration: 4.4 nM
The estimate for compound 3 lay 3.7-fold (0.56 log units) below the measured number; measured number above the stated range.
By their numbers in this assay, from the lowest: compounds 2 and 1 (each within the scatter of the next); then compound 3.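

Unlike the change of the link, the change of the ring moves the number beyond the scatter: this assay shows a 4.4-fold higher number from compound 2 to compound 3 (0.64 log units; beyond the scatter) as a modest but readable loss. Set against the amino-linked compound, the same ring gives a 2.9-fold higher number from compound 1 to compound 3 (0.47 log units; beyond the scatter) and is again beyond the scatter, so compound 3 stands apart from both oxan-4-yl compounds, whichever link they carry. Nothing available here explains why the five-membered ring gives the higher number.

On these data alone, it remains open whether this step follows the size of the ring or the place where the ring is attached, a question that oxolan-2-yl or oxetan-3-yl on the same chain carbon would bear on. Also open, as far as these compounds go, is whether a cyclohexyl ring, with no ring oxygen, would keep the number low.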